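Benzyloxy on the Distal Ring of a Cyanoazetidine Inhibitor

The compounds below may be only part of what the source reports. "The series", "measured", "known", "first", "only" and "open" are said of these compounds alone.

Measured compounds:
compound 1 `N#CN1CC(OCc2ccc(-c3ccccc3)cc2)C1`, 2.8 nM
compound 2 `N#CN1CC(Oc2ccc(-c3ccccc3)cc2)C1`, 29 nM
compound 3 `N#CN1CC(COCc2ccc(-c3ccccc3)cc2)C1`, 3.4 nM

In an assay on isolated protein for inhibition of N-acylethanolamine-hydrolyzing acid amidase (Homo sapiens), read by fluorescence, with a stated time of 90 min (on this read-out lower numbers stand for stronger inhibition and higher numbers for weaker inhibition), compound 1 gives the lowest of the three numbers. Compound 3 lies nearest, with a 1.2-fold higher number from compound 1 to compound 3 (0.08 log units; within the scatter), so these two cannot be told apart. Compound 2, whose value is 29 nM, gives the clearly higher number of the set, which is all that the pair of values shows.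

Compound 4 `N#CN1CC(OCc2ccc(-c3cccc(OCc4ccccc4)c3)cc2)C1` is the unmeasured analogue. It differs from compound 1 by benzyloxy in place of hydrogen on an aromatic carbon. None of the measured steps touches this part of the molecule: the one step shown, from compound 1 to compound 3, changes only the linker on the other side of the shared core, and it stayed within the scatter. Within the data shown here, no measured pair therefore speaks to a substituent on the distal aromatic ring, and the expectation must rest on compound 1 alone. The account expects that compound 4 stays close to compound 1, with a change of a 1.4-fold higher number from compound 1 to compound 4 (0.15 log units; within the scatter) in this assay, which is within the scatter. The estimate for compound 4 is 4 nM, with a range from 1.5 nM to 15 nM.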

Compound 4, half-maximal inhibitory concentration: 1.4 nM
For compound 4 the middle estimate is 2.9-fold (0.46 log units) above the measured one, outside the stated range (below it).
By their numbers in this assay, from the lowest: compounds 4, 1 and 3 (each within the scatter of the next, the first and the last beyond it); then compound 2.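

In this assay, benzyloxy in place of hydrogen on an aromatic carbon, meta to a large group, gives a 2.0-fold lower number from compound 1 to compound 4 (0.30 log units; within the scatter), so the two compounds cannot be told apart. Among these compounds, this is the first measured change at this position, and it shows that a group of 8 heavy atoms, bringing its own six-membered aromatic ring, can stand here without a step beyond the scatter, so the number remains in the range of compound 1 at 2.8 nM. Nothing shown accounts for this outcome, and no measurement bears on why the added group leaves the number where it is.

Because only one substituent at one place is shown, it remains open whether a small group such as methoxy, an amine, a carboxylic acid or a longer alkyl chain on this aromatic carbon would also leave the number within the scatter of compound 1. From the compounds shown here alone, it is equally open whether benzyloxy would behave the same way on another carbon of that ring, or on the linker variants seen in compound 2 and compound 3.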